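Oxan-4-yl in place of cyclohexyl on the shared core

A few compounds are considered here, and "the series" means these few. Any claim that something is new, unique, unknown or untested is made for them only; others in the source may bear on it.

Going by the values given here, compound 2 `O=C(C1CCCCC1)N1N=CCC1c1ccccc1` gives 5.9 in a physicochemical assay for lipophilicity, read by HPLC, measured as chromatographic lipophilicity, at pH 7.4 (on this read-out higher numbers stand for higher lipophilicity and lower numbers for lower lipophilicity), the higher of the two numbers measured so far. Compound 1 `O=C(c1cscn1)N1CCC(C(=O)N2N=CC[C@H]2c2ccccc2)CC1` gives 3 in this assay, which stands beyond the scatter below compound 2; no single change links these two. Compound 3 `O=C(C1CCOCC1)N1N=CCC1c1ccccc1` awaits measurement in this assay. Its change from compound 2 is oxan-4-yl in place of cyclohexyl on a carbonyl carbon. The step expected in this assay is a number 1.30 log units lower from compound 2 to compound 3 (beyond the scatter), downward and beyond the scatter. Compound 3 is estimated at 4.6, with a range from 4 to 5.2.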

Compound 3, distribution coefficient: 3.1
The estimate for compound 3 lay 1.50 log units above the measured number; the whole stated range lies above it.
By their numbers in this assay, from the lowest: compounds 1 and 3 (each within the scatter of the next); then compound 2.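

Going by these compounds alone, on a carbonyl carbon whose other neighbours are an amide-type nitrogen in a ring, oxan-4-yl in place of cyclohexyl provides the first single-change step: in this assay it gives a number 2.80 log units lower from compound 2 to compound 3 (beyond the scatter). The counted differences between the two groups are the ring hetero atom, an oxygen, and its 1 hydrogen-bond acceptor. Nothing available accounts for the size of this step. As far as these compounds go, how an amine such as piperidin-4-yl or a carboxylic acid would read at this position remains open. From the compounds shown here alone, whether the exchange gives a similar step on another core also remains open.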